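Lengthening a Side Chain: What Compound 4 Should Show

This account rests on a few compounds, and the source may have more. Where it says the series, first, only, none or still open, it means among the compounds named here.

Compound 1, `CC(C)=NNc1nc(-c2cccc([N+](=O)[O-])c2)cs1`, measured in a functional assay, with a stated time of 30 min; a lower number here means that less compound is needed, a higher number that more compound is needed for the effect: 510000 nM
Compound 2, `CCC/C(C)=N\Nc1nc(-c2cccc([N+](=O)[O-])c2)cs1`, in this assay: 550000 nM
Compound 3, `CCCC/C(C)=N\Nc1nc(-c2cccc([N+](=O)[O-])c2)cs1`, in this assay: 520000 nM

The three measured compounds share one core and differ only in the saturated chain attached to the carbon that carries a double bond to nitrogen. From compound 1 to compound 2 the change is ethyl in place of hydrogen on a saturated chain carbon bound to a carbon with a double bond to nitrogen, and the result is a 1.1-fold higher number from compound 1 to compound 2 (0.03 log units; within the scatter). The cores of compound 1 and compound 3 differ by propyl in place of hydrogen on a saturated chain carbon bound to a carbon with a double bond to nitrogen, which gave a 1.0-fold higher number from compound 1 to compound 3 (0.01 log units; within the scatter). Between compound 2 and compound 3 the step is a 1.1-fold lower number from compound 2 to compound 3 (0.02 log units; within the scatter). All three numbers lie within the scatter of one another, so this small set shows no effect of chain length at all.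

Compound 4, `CCCCCC/C(C)=N\Nc1nc(-c2cccc([N+](=O)[O-])c2)cs1`, is not yet measured. It differs from compound 3 by ethyl in place of hydrogen on a saturated chain carbon, four bonds along the chain from a carbon with a double bond to nitrogen. Going by the values given here, this is the same kind of change as the one from compound 1 to compound 2: there the ethyl entered on a saturated chain carbon bound to a carbon with a double bond to nitrogen, whereas here it enters on a saturated chain carbon four bonds along the chain from a carbon with a double bond to nitrogen. Because a 1.1-fold higher number from compound 1 to compound 2 (0.03 log units; within the scatter) stayed within the scatter, the step from compound 3 to compound 4 in this assay is expected to be a 1.0-fold higher number from compound 3 to compound 4 (0.01 log units; within the scatter). Compound 4 is therefore estimated to give 530000 nM, with an expected range from 300000 nM to 950000 nM.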

Compound 4, half-maximal effective concentration: 530000 nM
The estimate for compound 4 equals the measured number at the digits printed; measured number inside the range.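

In this assay, ethyl in place of hydrogen gave a 1.0-fold higher number from compound 3 to compound 4 (0.01 log units; within the scatter), and this step agrees with the earlier ethyl step made at a different place on the chain: the same change on two cores in this assay, a 1.1-fold higher number (0.03 log units; within the scatter) from compound 1 to compound 2 and a 1.0-fold higher number (0.01 log units; within the scatter) from compound 3 to compound 4, 1.1-fold (0.02 log units) apart, within the scatter of two such steps

Propyl in place of hydrogen gave a 1.0-fold lower number from compound 2 to compound 4 (0.02 log units; within the scatter), and this step likewise agrees with its earlier counterpart: the same change on two cores in this assay, a 1.0-fold higher number (0.01 log units; within the scatter) from compound 1 to compound 3 and a 1.0-fold lower number (0.02 log units; within the scatter) from compound 2 to compound 4, 1.1-fold (0.02 log units) apart, within the scatter of two such steps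

Pentyl in place of hydrogen gave a 1.0-fold higher number from compound 1 to compound 4 (0.02 log units; within the scatter), so all four compounds lie within the scatter of one another, and the matching steps show only that adding these plain saturated chains makes no measurable difference in this small series; they do not show that a change with a real effect would carry over from one core to another, as none of these steps is large enough to test that.

On these data alone, it remains open whether a still longer chain would move the number beyond the scatter. As far as these compounds go, it is equally open whether a chain ending in an amine, a carboxylic acid or a phenyl ring would do so, and whether any such step would then repeat on a second core.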